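Nitro Added to the Aryl Ring of a Tetrazole Hydrazone

The compounds below may be only part of what the source reports. "The series", "measured", "known", "first", "only" and "open" are said of these compounds alone.

Compound 1 `Cn1nnnc1SCC(=O)N/N=C/c1ccccc1` carries an unsubstituted phenyl ring on one end of its hydrazone. In an ADME assay on NIH3T3 cells (Mus musculus) for cytotoxicity, read by XTT assay, with a stated time of 24 h (on this read-out lower numbers stand for stronger inhibition and higher numbers for weaker inhibition), compound 1 gives 9700000 nM. Compound 2 `Cn1nnnc1SCC(=O)N/N=C/c1ccc(Br)cc1` adds a bromo group to that ring, and in this assay compound 2 gives 10000000 nM; the step of a 1.0-fold higher number from compound 1 to compound 2 (0.01 log units; within the scatter) lies within the scatter. Compound 3 `COc1ccc(/C=N/NC(=O)CSc2nnnn2C)cc1` carries a methoxy group instead, and in this assay compound 3 gives > 10000000 nM, which is a limit of the assay and not a number. The step of an at least 1.0-fold higher number from compound 1 to compound 3 (0.01 log units; that floor lies within the scatter) and the step of a number no lower from compound 2 to compound 3 (the limit leaves the size open) are therefore bounded on one side only, as shown by the limit of > 10000000 nM in this assay, at which 1 of the 3 values shown sits. Compound 1 and compound 2 thus sit within the scatter of each other, while compound 3 sits at the limit.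

Compound 4 `Cn1nnnc1SCC(=O)N/N=C/c1cccc([N+](=O)[O-])c1` differs from compound 1 by nitro in place of hydrogen on an aromatic carbon. The two measured ring substitutions, bromo and methoxy, produced no step beyond the scatter, so the expectation for nitro is the same: no step beyond the scatter, with a 1.0-fold lower number from compound 1 to compound 4 (0.01 log units; within the scatter) as the expected step. Compound 4 is therefore estimated at 9500000 nM, within a range from 3000000 nM to 10000000 nM.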

Compound 4, half-maximal inhibitory concentration: 2000000 nM
For compound 4 the middle estimate is 4.8-fold (0.68 log units) above the measured one; measured number outside the range, below it.
By their numbers in this assay, from the lowest: compound 4; then compounds 1 and 2 (each within the scatter of the next).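

Among these compounds, with nitro on the aromatic ring, this assay gives a 4.9-fold lower number from compound 1 to compound 4 (0.69 log units; beyond the scatter) and marks the first step in this small set to clear the scatter. This shows that the number does respond to a change on this ring: a substituent on an aromatic carbon, meta to a large group, can move it toward stronger inhibition, even though the step is modest in size and rests on one pair of compounds. Nothing among the measurements bears on why nitro has this effect, so the result stands as an observation about one group at one place.

The compounds shown do not separate the identity of the group from its place on the ring, since a single nitro compound cannot say whether the same group elsewhere on the ring would give a similar step. They also leave open whether other groups at this same place, such as an amine, a carboxylic acid or a longer chain like propyl, would move the number further, leave it unchanged or move it the other way.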